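Working notes: cytotoxicity of three related compounds

The source may report more compounds than this note shows. Statements on the series, on what has been measured and on what is new or still open speak of the compounds shown alone.

Measured in an ADME assay on MT4 cells (Homo sapiens) for cytotoxicity, read by MTT assay, with a stated time of 4 days; on this read-out higher numbers stand for lower toxicity in this test and lower numbers for higher toxicity in this test:
- compound 1 `O=c1ccn(CCOc2ccc(Cl)cc2)c(=O)n1Cc1ccccc1`: 36000 nM
- compound 2 `Cc1ccc(OCCn2ccc(=O)n(Cc3ccccc3C)c2=O)cc1`: 46000 nM

Compound 2, at 46000 nM, lies within the usual scatter of compound 1, at 36000 nM, so the two values cannot be told apart. The next compound to be tested is compound 3 `Cc1ccc(OCCn2ccc(=O)n(C(C)c3ccccc3)c2=O)cc1`, which has 1-phenylethyl in place of 2-methylbenzyl on an aromatic nitrogen. Going by the values given here, the two measured compounds do not differ in one place only, so no measured step speaks directly to this swap. Among the compounds with values here, the only guide is how close the values of compound 1 and compound 2 lie, and no step beyond the scatter is expected in this assay. The estimated change is a 1.2-fold lower number from compound 2 to compound 3 (0.06 log units; within the scatter), which would stay within the scatter. For compound 3 the expected value is 40000 nM, with an estimated range of 18000 nM to 90000 nM.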

Compound 3, half-maximal cytotoxic concentration: 132000 nM
The estimate for compound 3 lay 3.3-fold (0.52 log units) below the measured number; measured number above the stated range.
By their numbers in this assay, from the lowest: compounds 1 and 2 (each within the scatter of the next); then compound 3.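

In this assay, going by these compounds alone, 1-phenylethyl in place of 2-methylbenzyl on the aromatic nitrogen gives a 2.9-fold higher number from compound 2 to compound 3 (0.46 log units; beyond the scatter), a modest step in the direction of lower toxicity in this test and the first step that changes one place only. The two groups have the same atoms, joined differently, so this position responds to a rearrangement alone, with no change in heavy atoms, hydrogen-bond donors, hydrogen-bond acceptors or charge. Nothing at hand accounts for the step.

The step moves the methyl of 2-methylbenzyl and creates the branch of 1-phenylethyl in one change, and compound 1 differs from compound 2 in more than one place, so the two features stay unseparated. Going by these compounds, how a longer chain, an amine or a carboxylic acid on this nitrogen would read remains open.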